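Swapping Trifluoromethyl for Isopropoxy: Expected Cytotoxicity

This account rests on a few compounds, and the source may have more. Where it says the series, first, only, none or still open, it means among the compounds named here.

Three related compounds were tested in an ADME assay on L6 cells (Rattus norvegicus) for cytotoxicity, read by resazurin assay, with a stated time of 72 h; a lower number here means a stronger inhibitor, a higher number a weaker inhibitor. Compound 1 `CC(C)Oc1cccc(C(O)(c2ccc(Cl)cc2)c2cccnc2)c1` gives 67600 nM, compound 2 `CC(C)Oc1ccc(C(O)(c2ccc(C(F)(F)F)cc2)c2cccnc2)cc1` gives 47600 nM, and compound 3 `OC(c1ccc(Cl)cc1)(c1cccnc1)c1cccc(C(F)(F)F)c1` gives 60400 nM; all three lie within the scatter of one another. The change isopropoxy in place of trifluoromethyl on an aromatic carbon made from compound 3 to compound 1 gave a 1.1-fold higher number from compound 3 to compound 1 (0.05 log units; within the scatter). Compound 4 `CC(C)Oc1ccc(C(O)(c2ccc(OC(C)C)cc2)c2cccnc2)cc1` arises from compound 2 by isopropoxy in place of trifluoromethyl on an aromatic carbon. The difference between the cores of compound 2 and compound 3 is not broken down here. The place is not identical: in compound 1 the isopropoxy is meta to a large group, in compound 4 it is para to a large group, so this is the same kind of change, not the same change. Because the earlier change gave a 1.1-fold higher number from compound 3 to compound 1 (0.05 log units; within the scatter), the step from compound 2 to compound 4 is expected to be a 1.2-fold higher number from compound 2 to compound 4 (0.06 log units; within the scatter). Compound 4 is therefore estimated at 55000 nM, between 30000 nM and 110000 nM.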

Compound 4, half-maximal inhibitory concentration: 61400 nM
Estimate against measurement, compound 4: 1.1-fold (0.05 log units) below; low and high end bracket the measured number.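

In this assay, putting isopropoxy in place of trifluoromethyl gave a 1.3-fold higher number from compound 2 to compound 4 (0.11 log units; within the scatter). Set beside the earlier case, the same change behaved alike on the two cores, with no difference that can be told apart from ordinary assay noise: the same change on two cores in this assay, a 1.1-fold higher number (0.05 log units; within the scatter) from compound 3 to compound 1 and a 1.3-fold higher number (0.11 log units; within the scatter) from compound 2 to compound 4, 1.2-fold (0.06 log units) apart, within the scatter of two such steps. This shows that on these two cores the change left the number within the scatter, but it does not show that this would hold on any other core, and such small steps give no reason for the result.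

The compounds shown leave open whether a different group in that place, such as an amine, a carboxylic acid or a longer chain, would move the number beyond the scatter.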